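A few compounds are considered here, and "the series" means these few. Any claim that something is new, unique, unknown or untested is made for them only; others in the source may bear on it.

Measured compounds:
- compound 1 `CN1Cc2c(Cl)cc(Cl)cc2C(c2cccc(S(N)(=O)=O)c2)C1`, giving 631 nM in an assay on cells (Kidney epithelial cell, kidney) for inhibition of sodium/hydrogen exchanger 3 (Homo sapiens), read by fluorescence, in the presence of a further agent that is not named here; on this read-out higher numbers stand for weaker inhibition and lower numbers for stronger inhibition
- compound 2 `CN1Cc2c(Cl)cc(Cl)cc2[C@@H](c2cccc(NC(=O)[C@H](O)[C@@H](O)[C@H](O)[C@H](O)CO)c2)C1`, giving 2510 nM in this assay

Of the two measured compounds, compound 1 gives the lower number in this assay, and the value of compound 2 stands well above it, a gap that lies beyond the usual scatter of this read-out. For the measured compounds named here, compound 2 differs from compound 1 in more than one place, so no single step is drawn between them; only the two values themselves are known.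

The step considered here leads from compound 1 to compound 3 `CN1Cc2c(Cl)cc(Cl)cc2C(c2cccc(S(=O)(=O)NCC(=O)O)c2)C1`. The change is carboxymethyl in place of hydrogen on a sulfonamide nitrogen. Going by the values given here, nothing among the measured compounds shows the effect of this particular change, since compound 2 carries its polar chain on an entirely different group.

Compound 3 is therefore expected to give a number close to that of compound 1, with a small step toward weaker inhibition as the more likely direction, of about a 1.4-fold higher number from compound 1 to compound 3 (0.15 log units; within the scatter). The estimate for compound 3 in this assay is 900 nM, with a range from 300 nM to 3000 nM.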

Compound 3, half-maximal inhibitory concentration: 100 nM
Compound 3: middle estimate off by 9.0-fold (0.95 log units), on the high side, and the stated range ends above it.
By their numbers in this assay, from the lowest: compound 3; then compound 1; then compound 2.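

In this assay, the sulfonamide nitrogen of compound 1 turns out to accept a carboxymethyl group with a stronger inhibition as the result, and the change gives a 6.3-fold lower number from compound 1 to compound 3 (0.80 log units; beyond the scatter), a step beyond the usual scatter of the read-out. The hydrogen on this nitrogen is therefore not required for inhibition in this series, and a substituent ending in a carboxylic acid is tolerated here, with compound 3 reaching 100 nM as the lowest number of the three compounds shown. No measurement among these compounds accounts for the size or direction of this step.

On these data alone, what remains open is which part of the new group carries the step: the carboxylic acid itself, or simply the added chain, a question that the methyl ester, the primary amide or a longer chain such as carboxyethyl on the same nitrogen would address. As far as these compounds go, it is also open whether an amine at the end of the same chain, or a second substituent on this nitrogen, would keep the lower number seen with compound 3.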